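Trading a Protected Amine for a Free One

This account rests on a few compounds, and the source may have more. Where it says the series, first, only, none or still open, it means among the compounds named here.

Compound 2 `CC(C)(C)OC(=O)NCCNC(=O)CN1CN(c2ccccc2)C2(CCN(C(=O)c3ccc(C(C)(C)C)cc3)CC2)C1=O` gives the highest of the three numbers in an assay on HEK293 cells for displacement of a labelled ligand from NPC1-like intracellular cholesterol transporter 1 (Homo sapiens) (on this read-out lower numbers stand for stronger inhibition and higher numbers for weaker inhibition), with 10900 nM. Compound 1 `O=C(CN1CN(c2ccccc2)C2(CCN(C(=O)c3ccc(C4CCCCC4)cc3)CC2)C1=O)NCCCCO`, at 10300 nM, stands within the scatter of it, while compound 3 `COC(=O)CCCNC(=O)CN1CN(c2ccccc2)C2(CCN(C(=O)c3ccc(C4CCCCC4)cc3)CC2)C1=O`, at 2500 nM, lies beyond it. Compound 4 `CC(C)(C)c1ccc(C(=O)N2CCC3(CC2)C(=O)N(CC(=O)NCCCN)CN3c2ccccc2)cc1` differs from compound 2 in one place: aminomethyl in place of (tert-butoxycarbonyl)amino on a saturated chain carbon, two bonds along the chain from an amide-type nitrogen. For the measured compounds named here, no measured pair shows this same change. Going by the values given here, the only measured step, a 4.1-fold lower number from compound 1 to compound 3 (0.61 log units; beyond the scatter), concerns a different group at a different place and offers no guide here. With nothing bearing on the change, a step of a 1.2-fold lower number from compound 2 to compound 4 (0.08 log units; within the scatter) is expected, that is, none beyond the scatter. Compound 4 is therefore estimated at 9000 nM, within 3000 nM to 30000 nM.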

Compound 4, half-maximal inhibitory concentration: 4200 nM
The estimate for compound 4 lay 2.1-fold (0.33 log units) above the measured number; the range from low to high includes it.
By their numbers in this assay, from the lowest: compounds 3 and 4 (each within the scatter of the next); then compounds 1 and 2 (each within the scatter of the next).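

Putting aminomethyl in place of (tert-butoxycarbonyl)amino on this saturated chain carbon gives a 2.6-fold lower number from compound 2 to compound 4 (0.41 log units; beyond the scatter) in this assay. This shows that the number responds to the group at this place, and that the 8 heavy atoms of the protected group are not required, since the 2 heavy atoms of aminomethyl give the lower number. No available evidence explains the step.

The compounds shown leave open how a 2-aminoethyl end, with a shorter chain, would compare with 3-aminopropyl. They also leave open what a longer chain ending in an amine, or a carboxylic acid at that end, would do.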